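The compounds below may be only part of what the source reports. "The series", "measured", "known", "first", "only" and "open" are said of these compounds alone.

Measured compounds and their values:
- Compound 1 `Cn1cc(-c2cnc(NCc3c(F)ccc4c3CCO4)c3cn[nH]c(=O)c23)cn1`: 2.7
- Compound 2 `CN(C)Cc1ccc(C(=O)Nc2cnc(NCc3c(F)ccc4c3CCO4)n3cnnc23)cc1`: 1.8
- Compound 3 `O=C(Nc1cnc(NCc2c(F)ccc3c2CCO3)n2cnnc12)c1cccnc1`: 2

All three were measured in a physicochemical assay for lipophilicity, using the shake flask method, in phosphate buffer, measured as octanol-water partition, with a stated time of 30 min, at pH 7.4; on this read-out lower numbers stand for lower lipophilicity and higher numbers for higher lipophilicity. Among them compound 1 stands highest, beyond the scatter above both compound 3 and compound 2; compound 3 and compound 2 lie within the scatter of each other, as the step of a number 0.20 log units higher from compound 2 to compound 3 (within the scatter) shows.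

Compound 4 `CNC(=O)c1ccc(-c2cnc(NCc3c(F)ccc4c3CCO4)c3cn[nH]c(=O)c23)c(C)n1` has not yet been measured. It differs from compound 1 in one place: 2-methyl-6-(methylcarbamoyl)pyridin-3-yl in place of 1-methyl-1H-pyrazol-4-yl on an aromatic carbon. Within the data shown here, no measured step mirrors this change. Among the measured compounds shown here, the only measured step, a number 0.20 log units higher from compound 2 to compound 3 (within the scatter), swaps one aryl group for another on a carbonyl carbon of a different core and was within the scatter, so it says only that such an aryl swap need not move the number much. The entering group is larger and brings an amide with one hydrogen-bond donor, the leaving group is a small five-membered ring; these pull in opposite ways. Compound 4 is therefore expected to land close to compound 1, with a small step of a number 0.20 log units lower from compound 1 to compound 4 (within the scatter) that may sit within the scatter. The estimate for compound 4 is 2.5, within the range 1.9 to 3.1.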

Compound 4, distribution coefficient: 2.9
Compound 4: the middle estimate sits 0.40 log units below what was measured; low and high end bracket the measured number.
By their numbers in this assay, from the lowest: compounds 2 and 3 (each within the scatter of the next); then compounds 1 and 4 (each within the scatter of the next).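

In this assay, the swap at this aromatic carbon of the shared core gives a number 0.20 log units higher from compound 1 to compound 4 (within the scatter), the first step read at this position, since the earlier step concerned a carbonyl carbon on a different core. Although the entering 2-methyl-6-(methylcarbamoyl)pyridin-3-yl has 11 heavy atoms and a hydrogen-bond donor, against 6 heavy atoms and no donor in 1-methyl-1H-pyrazol-4-yl, the two compounds lie within the scatter of each other. No measurement here explains why these two quite different groups give such similar numbers.

This single pair cannot separate what the pyridine ring and the methylcarbamoyl group each contribute. It also leaves open whether the number would hold with a carboxylic acid or a piperidine at this position.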